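This account rests on a few compounds, and the source may have more. Where it says the series, first, only, none or still open, it means among the compounds named here.

- Compound 1 `CC(=O)OC[C@H]1O[C@@H](n2c(SCc3cc4ccccc4oc3=O)nc3cncnc32)[C@H](OC(C)=O)[C@@H]1OC(C)=O`: 39000 nM
- Compound 2 `CC(=O)OC[C@H]1O[C@@H](n2c(SCc3cc4ccccc4oc3=O)nc3cncnc32)[C@H](O)[C@@H]1O`: 8700 nM

Both compounds were tested in a functional assay on Huh-5-2 cells (Homo sapiens) for cytotoxicity, read by microscopy; on this read-out higher numbers stand for lower toxicity in this test and lower numbers for higher toxicity in this test. Compound 2 holds the lower of the two numbers at 8700 nM, while compound 1 gives 39000 nM. The gap lies beyond the usual scatter, so compound 2 is the more toxic of the pair in this test.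

Compound 3 `CC(=O)OC[C@H]1O[C@@H](n2c(SCc3cc4cc(Br)ccc4oc3=O)nc3cncnc32)[C@H](O)[C@@H]1O` differs from compound 2 in one place, with bromo in place of hydrogen on an aromatic carbon. Among the compounds with values here, no measured pair shows what this kind of change does, so any expectation is loose. The likely outcome is a small step in this assay, probably none beyond the scatter, with a slight lean towards a lower number. The estimated step is a 1.2-fold lower number from compound 2 to compound 3 (0.09 log units; within the scatter). The expected value for compound 3 is 7000 nM, with an estimated range from 2500 nM to 25000 nM.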

Compound 3, half-maximal cytotoxic concentration: 31000 nM
Estimate against measurement, compound 3: 4.4-fold (0.65 log units) below; the whole stated range lies below it.
By their numbers in this assay, from the lowest: compound 2; then compounds 3 and 1 (each within the scatter of the next).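

In this assay, bromo in place of hydrogen on this aromatic carbon, meta to a fused ring and para to a fused ring, gives a 3.6-fold higher number from compound 2 to compound 3 (0.55 log units; beyond the scatter) in a single change. This shows that the position is not silent: one added bromine atom moves the number by more than the usual scatter, in the direction of lower toxicity in this test. Nothing available explains why the number moves in this way.

The compounds shown leave open whether chloro, fluoro, methoxy or an amine on this same carbon would shift the number in the same direction, and by a similar amount. Within the data shown here, with only one such step, it also remains open whether bromo would have the same effect on the core of compound 1.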